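The source may report more compounds than this note shows. Statements on the series, on what has been measured and on what is new or still open speak of the compounds shown alone.

Compound 2 `C[C@@H](O)[C@H]1C(=O)N2C(C(=O)OCOC(=O)OC(C)(C)C)=C(S[C@@H]3CN[C@H](C(=O)Nc4cccc(C(=O)O)c4)C3)[C@H](C)[C@H]12` is the starting point of this comparison. In a physicochemical assay for metabolic stability, read by LC-MS, in phosphate buffer, with a stated time of 3 h, at pH 7.4, tested at 50 uM (a higher number here means that more of the compound is left, a lower number that less of the compound is left), compound 2 gives > 95%, and this is a limit of the assay rather than a number. Compound 1 `CCOC(=O)C1=C(S[C@@H]2CN[C@H](C(=O)Nc3cccc(C(=O)OCC)c3)C2)[C@H](C)[C@@H]2[C@@H]([C@@H](C)OC(=O)CC)C(=O)N12` in this assay gives > 95%, again a limit. Compound 3 `C[C@@H](O)[C@H]1C(=O)N2C(C(=O)OCOC(=O)OC(C)(C)C)=C(S[C@@H]3CN[C@H](C(=O)Nc4cccc(C(=O)OCOC(=O)OC(C)(C)C)c4)C3)[C@H](C)[C@H]12` in this assay gives > 95%, which is also a limit. Within the data shown here, because of the limit of > 95% in this assay, at which 3 of the 3 values shown sit, no compound measured so far has given a readable number.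

Compound 4 `CCOC(=O)C1=C(S[C@@H]2CN[C@H](C(=O)Nc3cccc(C(=O)O)c3)C2)[C@H](C)[C@@H]2[C@@H]([C@@H](C)O)C(=O)N12` has not yet been measured; it differs from compound 2 as methyl in place of (tert-butoxycarbonyl)oxy on a saturated chain carbon bound to an oxygen next to a carbonyl group. Among the measured compounds shown here, the only measured step that touches the same part of the molecule is a step that the two limits leave unreadable from compound 2 to compound 3, and its size cannot be read, since both of its ends are limits. Compound 1 and compound 3, with other changes elsewhere, also reach the limit.

For compound 4 no step beyond the scatter in this assay is therefore expected, and the step that the limit leaves unreadable from compound 2 to compound 4 is estimated to be essentially none. Compound 4 is estimated at 96%, in a range from 88% to 100%.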

Compound 4, percent of the compound remaining: > 95%
Compound 4: only a limit was reported (the forecaster's own chance of this, stated with the estimate: 80%); the middle value is on the limit's open side.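

Because compound 2 and compound 4 both give a limit rather than a number, no step from one to the other can be read: the limit of > 95% in this assay, at which 4 of the 4 values shown sit.

The compounds shown leave open whether any of the changes among them alters how much compound remains in this assay, as none of them gives a readable number.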